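This account rests on a few compounds, and the source may have more. Where it says the series, first, only, none or still open, it means among the compounds named here.

Measured so far:
compound 1 `CCOc1ncc(-c2nc(C(F)(F)F)sc2N2CCN(C(=O)Cn3cnc4cccnc43)[C@H](C)C2)cn1`; in a functional assay on U2OS cells for antagonist activity at C-X-C chemokine receptor type 3 (Homo sapiens), read by beta-arrestin recruitment (a lower number here means a stronger inhibitor, a higher number a weaker inhibitor), compound 1 gives 20 nM.
compound 2 `CCOc1ncc(-c2nc(C(F)(F)F)sc2N2CCN(C(=O)Cn3nccc3C)[C@H](C)C2)cn1`; in this assay compound 2 gives 162 nM.

Compound 2 holds the highest of the two numbers; its nearest neighbour is compound 1, separated from it by an 8.1-fold higher number from compound 1 to compound 2 (0.91 log units; beyond the scatter). The next step goes to the unmeasured compound 3 `CCOc1ncc(-c2nc(C(F)(F)F)sc2N2CCN(C(=O)Cn3cnc(C(F)(F)F)n3)[C@H](C)C2)cn1`, and the change is 3-(trifluoromethyl)-1H-1,2,4-triazol-1-yl in place of 5-methyl-1H-pyrazol-1-yl on a saturated chain carbon bound to a carbonyl carbon. For the measured compounds named here, only one measured step bears on it: an 8.1-fold higher number from compound 1 to compound 2 (0.91 log units; beyond the scatter), in which the group of compound 1 gave way to that of compound 2 and the number rose clearly. Going by the values given here, compound 3 carries a group that is neither of those two, so that step offers only loose guidance, and no measured pair shows a trifluoromethyl-bearing five-membered ring at this place. The expected step in this assay is therefore modest, a 1.5-fold lower number from compound 2 to compound 3 (0.17 log units; within the scatter), toward a somewhat lower number than compound 2, with wide uncertainty in either direction. Compound 3 is estimated at 110 nM, with a range from 30 nM to 450 nM.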

Compound 3, half-maximal inhibitory concentration: 118 nM
Beside the measured number, compound 3's estimate is 1.1-fold (0.03 log units) below it, and the stated range covers the measured number.
By their numbers in this assay, from the lowest: compound 1; then compounds 3 and 2 (each within the scatter of the next).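

In this assay, 3-(trifluoromethyl)-1H-1,2,4-triazol-1-yl in place of 5-methyl-1H-pyrazol-1-yl on a saturated chain carbon bound to a carbonyl carbon gives a 1.4-fold lower number from compound 2 to compound 3 (0.14 log units; within the scatter), so these two single five-membered aromatic rings cannot be told apart at this position, although the ring and its substituent both differ. The group of compound 3 and the two-ring group of compound 1 have the same heavy-atom count, yet the data show a 5.9-fold higher number from compound 1 to compound 3 (0.77 log units; beyond the scatter), so heavy-atom count alone does not separate compound 1 from compound 3 at this position. No supporting data accompany these results that could account for this gap.

Because the ring and its substituent change together from compound 2 to compound 3, the separate contribution of each stays unresolved, and the near-equal values could reflect either two small effects or two larger opposing ones. Also open, going by these compounds, is whether the number of compound 1 depends on an aromatic group at all, which a morpholine or a simple dimethylamino group on the same chain carbon would test.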